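Swapping Fluoro for Acetamido on a Cytotoxic Scaffold

This account rests on a few compounds, and the source may have more. Where it says the series, first, only, none or still open, it means among the compounds named here.

For the measured compounds named here, in a functional assay on HepG2 cells (Homo sapiens) for cytotoxicity, read by MTT assay, with a stated time of 24 h (a lower number here means a stronger inhibitor, a higher number a weaker inhibitor), compound 1 (`N#Cc1ccc(/C=C2\CN(S(=O)(=O)c3ccc(F)cc3)C/C(=C\c3ccc(C#N)cc3)C2=O)cc1`) gives 11500 nM, the higher of the two numbers measured so far. Compound 2 (`COc1cc(/C=C2\CN(S(=O)(=O)c3ccc(F)cc3)C/C(=C\c3cc(OC)cc(OC)c3)C2=O)cc(OC)c1`) gives 8100 nM, which lies within the scatter of that value. Compound 3 (`CC(=O)Nc1ccc(S(=O)(=O)N2C/C(=C\c3ccc(C#N)cc3)C(=O)/C(=C/c3ccc(C#N)cc3)C2)cc1`) keeps the core of compound 1 and differs in one place: acetamido in place of fluoro on an aromatic carbon. It carries acetamido in place of fluoro on an aromatic carbon, para to a large group, so that 4-fluorophenyl becomes 4-acetamidophenyl. Going by the values given here, no measured pair shows this change, so the data offer no direct guide to it. Also carrying the 4-fluorophenyl group and differing from compound 1 elsewhere, compound 2 with its 8100 nM stays within the scatter. In this assay, the expected outcome is therefore a 1.2-fold lower number from compound 1 to compound 3 (0.08 log units; within the scatter), a step estimated to stay within the scatter. Compound 3 is expected at 9500 nM, with an estimated range of 3500 nM to 28000 nM.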

Compound 3, half-maximal inhibitory concentration: 4880 nM
Compound 3: middle estimate off by 1.9-fold (0.29 log units), on the high side; the range from low to high includes it.
By their numbers in this assay, from the lowest: compounds 3, 2 and 1 (each within the scatter of the next, the first and the last beyond it).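

In this assay, replacing fluoro with acetamido gives a 2.4-fold lower number from compound 1 to compound 3 (0.37 log units; beyond the scatter), so this position, on an aromatic carbon para to a large group, responds to the identity of its substituent. Compounds 1 and 2 both carry the 4-fluorophenyl group and could not show this; compound 3 shows that the larger acetamido group, with its hydrogen-bond donor and acceptor, is accepted here without any loss in this assay. No measurement at hand explains the modest step.

Going by these compounds, it remains open whether an amine or a longer acyl chain such as propionamido at the same place would go further in the same direction, or would reverse the step. On these data alone, it is also open whether 4-acetamidophenyl would have a similar effect alongside the other aromatic groups of compound 2.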